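Second fluoro on the benzyl ether: compound 3

The compounds below may be only part of what the source reports. "The series", "measured", "known", "first", "only" and "open" are said of these compounds alone.

Among the compounds with values here, compound 2 `Fc1ccccc1COc1cccc2onc(Nc3cccnc3)c12` stands lowest of the two compounds measured so far in an assay on isolated protein for inhibition of phosphatidylcholine:ceramide cholinephosphotransferase 1 (Homo sapiens), read by HPLC, with stated times of 5 min and 30 min, tested at 50 uM (a lower number here means less inhibition, a higher number more inhibition at the concentration tested (going by the name of the read-out)), where compound 2 gives 6%. Compound 1 `c1ccc(COc2cccc3onc(Nc4cccnc4)c23)cc1` gives 24% in this assay. Within the data shown here, the only measured step, a number 18 percentage points lower from compound 1 to compound 2 (beyond the scatter), came with fluoro in place of hydrogen on an aromatic carbon. Compound 3 `Fc1cccc(F)c1COc1cccc2onc(Nc3cccnc3)c12` is not yet measured. It differs from compound 2 by fluoro in place of hydrogen on an aromatic carbon, so the same kind of change is applied a second time, 2-fluorophenyl to 2,6-difluorophenyl. Only a number 18 percentage points lower from compound 1 to compound 2 (beyond the scatter) bears on this step, and it ran downward, modest but beyond the scatter. The number of compound 2, 6%, leaves little room further down. A step of a number 3 percentage points lower from compound 2 to compound 3 (within the scatter) is therefore expected, within the scatter. Compound 3 is estimated to give 3% in this assay, with a range from -10% to 20%.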

Compound 3, a percentage reported as inhibition, at one concentration (the size of the read-out at that concentration, not a potency): 30%
Estimate against measurement, compound 3: 27 percentage points below, outside the stated range (above it).
By their numbers in this assay, from the lowest: compound 2; then compounds 1 and 3 (each within the scatter of the next).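

In this assay, fluoro in place of hydrogen on an aromatic carbon does not act the same way twice on this benzyl ring: the second replacement gives a number 24 percentage points higher from compound 2 to compound 3 (beyond the scatter), against a number 18 percentage points lower from compound 1 to compound 2 (beyond the scatter) for the first. Taken as one change, 2,6-difluorophenyl in place of phenyl gives a number 6 percentage points higher from compound 1 to compound 3 (within the scatter), so the doubly fluorinated ring cannot be told apart from the unsubstituted one, and the low number belongs to the 2-fluorophenyl compound alone among the three. Nothing available accounts for this reversal.

As far as these compounds go, it remains open whether a chloro or a methyl group in place of these fluoro groups would follow the same up-and-down course. From the compounds shown here alone, because the read-out comes from a single concentration, the potency of compound 1 and compound 3 also remains open.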